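Adding a methoxy group to a tamoxifen-like scaffold

This account rests on a few compounds, and the source may have more. Where it says the series, first, only, none or still open, it means among the compounds named here.

Measured compounds:
- compound 1 `CC/C(=C(\c1ccccc1)c1ccc(NC(=O)C(C)C)cc1)c1ccc(OCc2ccccc2)cc1`: 10200 nM
- compound 2 `CC/C(=C(/c1ccc(NC(=O)C(C)C)cc1)c1ccc(OC)cc1)c1ccc(OCc2ccccc2)cc1`: 4200 nM
- compound 3 `CC/C(=C(/c1ccccc1)c1ccc(NC(=O)C(C)C)cc1)c1ccccc1`: 28100 nM

In a functional assay on HeLa cells (Homo sapiens) for inhibition, read by trypan blue exclusion, with a stated time of 72 h (on this read-out higher numbers stand for weaker inhibition of growth and lower numbers for stronger inhibition of growth), compound 1 gives 10200 nM and compound 2 gives 4200 nM. The change between them is methoxy in place of hydrogen on an aromatic carbon, and it made a 2.4-fold lower number from compound 1 to compound 2 (0.39 log units; beyond the scatter). Compound 3 gives 28100 nM, the highest number of the three; the difference between its core and that of compound 1 is not broken down here. Compound 4 `CC/C(=C(\c1ccc(NC(=O)C(C)C)cc1)c1ccc(OC)cc1)c1ccccc1` is not yet measured; it differs from compound 3 by methoxy in place of hydrogen on an aromatic carbon, the same change as from compound 1 to compound 2. If it acts the same way, the step expected in this assay is a 2.3-fold lower number from compound 3 to compound 4 (0.37 log units; beyond the scatter), resting on compound 1 and a 2.4-fold lower number from compound 1 to compound 2 (0.39 log units; beyond the scatter). Compound 4 is therefore estimated at 12000 nM, likely between 6000 nM and 25000 nM.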

Compound 4, concentration for 50% growth inhibition: 10100 nM
Beside the measured number, compound 4's estimate is 1.2-fold (0.07 log units) above it, and the stated range covers the measured number.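

In this assay the change from phenyl to 4-methoxyphenyl gave a 2.8-fold lower number from compound 3 to compound 4 (0.44 log units; beyond the scatter) and so repeated, on a second core, the step already seen on the core of compound 1. The two steps agree in size: the same change on two cores in this assay, a 2.4-fold lower number (0.39 log units; beyond the scatter) from compound 1 to compound 2 and a 2.8-fold lower number (0.44 log units; beyond the scatter) from compound 3 to compound 4, 1.1-fold (0.06 log units) apart, within the scatter of two such steps. This shows that the methoxy change carried over between these two cores in this one growth read-out, but two pairs of compounds make no rule for the whole series and do not reveal why the numbers fall.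

The compounds shown leave open whether another group on that same aromatic carbon, such as hydroxyl, ethoxy or fluorine, would give a similar step. They also leave open whether the step would hold on a core carrying an amine side chain.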